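The source may hold more compounds than are shown below. What is called first, only, known or untested is meant among the compounds shown, and "the series" means these compounds.

Compound 1 `COc1ccc(/C=N/N(Cc2ccccc2)Cc2ccccc2)cc1` gives 220 nM in an assay on liver (Sus scrofa) for inhibition of glucose-6-phosphatase catalytic subunit 1 (Homo sapiens), using microsomes; on this read-out higher numbers stand for weaker inhibition and lower numbers for stronger inhibition. Compound 2 `COc1ccccc1/C=N/N(Cc1ccccc1)Cc1ccccc1` reaches only a limit of this assay, > 100000 nM. Compound 3 `Oc1ccc(/C=N/N(Cc2ccccc2)Cc2ccccc2)cc1` gives 2400 nM; the step of an 11-fold higher number from compound 1 to compound 3 (1.04 log units; beyond the scatter) places compound 3 at the highest of the two numbers, with compound 1 nearest. Compound 4 `Clc1cc(Cl)cc(/C=N/N(Cc2ccccc2)Cc2ccccc2)c1` is not yet measured; it differs from compound 3 by 3,5-dichlorophenyl in place of 4-hydroxyphenyl on a carbon with a double bond to nitrogen. Among the measured compounds shown here, no measured step exchanges the 4-hydroxyphenyl for a 3,5-dichlorophenyl; the nearest evidence is an 11-fold higher number from compound 1 to compound 3 (1.04 log units; beyond the scatter), where hydrogen in place of methyl on the oxygen raised the number, and an at least 450-fold higher number from compound 1 to compound 2 (2.65 log units; beyond the scatter), which ended at the limit of > 100000 nM in this assay, at which 1 of the 3 values shown sits. A moderate step downward is therefore expected, a 4.8-fold lower number from compound 3 to compound 4 (0.68 log units; beyond the scatter). Compound 4 is estimated at 500 nM, range 80 nM to 5000 nM.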

Compound 4, half-maximal inhibitory concentration: > 100000 nM
Compound 4: only a limit was reported; the forecaster's own chance of this, stated with the estimate: 10%; at least 200-fold (2.30 log units) between middle value and limit.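

In this assay, 3,5-dichlorophenyl on a carbon with a double bond to nitrogen gives an at least 41-fold higher number from compound 3 to compound 4 (1.61 log units; beyond the scatter) and an at least 450-fold higher number from compound 1 to compound 4 (2.65 log units; beyond the scatter). Among the four compounds, readable values now come only with 4-methoxyphenyl and 4-hydroxyphenyl, while a group with no oxygen ends in the same place as 2-methoxyphenyl. The result for compound 4 is a limit, not a number, and the step between compound 2 and compound 4 cannot be read: the limit of > 100000 nM in this assay, at which 2 of the 4 values shown sit.

Open, from the compounds shown here alone, is whether 4-chlorophenyl or 4-aminophenyl would keep a readable value. The compounds shown also do not separate the effect of the chlorines themselves from that of their placement.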